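Shortening the Side Chain on Two Related Chromanone Cores

The compounds below may be only part of what the source reports. "The series", "measured", "known", "first", "only" and "open" are said of these compounds alone.

Measured compounds:
Compound 1, `CC/C=C\C/C=C\C/C=C\CCCCCCCC1(O)CC(=O)c2c(O)cc(OCOC)cc2O1`: 17500 nM
Compound 2, `CCCC/C=C\CCCCCCCCCC1(O)CC(=O)c2c(O)cc(OCOC)cc2O1`: 43200 nM
Compound 3, `CC/C=C\C/C=C\C/C=C\CCCCCCCc1cc(=O)c2c(O)c(C)c(O)c(C)c2o1`: 17500 nM

All three were tested in a functional assay on MCF7 cells (Homo sapiens) for antiproliferative activity, read by MTT assay; a higher number here means a weaker inhibitor, a lower number a stronger inhibitor. Compound 1 and compound 3 sit level at the digits printed, and compound 2 stands apart from both. Between compound 1 and compound 2 the change is a group of 8 heavy atoms (8 carbon; no ring) in place of a group of 10 heavy atoms (10 carbon; no ring), on a saturated chain carbon, seven bonds along the chain from a saturated ring carbon, and it gave a 2.5-fold higher number from compound 1 to compound 2 (0.39 log units; beyond the scatter). Compound 4, `CCCC/C=C\CCCCCCCCCc1cc(=O)c2c(O)c(C)c(O)c(C)c2o1`, has not yet been measured. Its difference from compound 3 is a group of 8 heavy atoms (8 carbon; no ring) in place of a group of 10 heavy atoms (10 carbon; no ring), on a saturated chain carbon, seven bonds along the chain from an aromatic carbon. Going by the values given here, this is the same kind of change as the one from compound 1 to compound 2, though there the chain sits seven bonds along the chain from a saturated ring carbon, while in compound 4 it sits seven bonds along the chain from an aromatic carbon. The difference between the two cores is not broken down here. The step from compound 3 to compound 4 is expected to be a 2.5-fold higher number from compound 3 to compound 4 (0.39 log units; beyond the scatter), resting on the single earlier case in which the same change gave a 2.5-fold higher number from compound 1 to compound 2 (0.39 log units; beyond the scatter). Compound 4 is therefore estimated at 43000 nM, with a likely range from 18000 nM to 100000 nM.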

Compound 4, half-maximal inhibitory concentration: > 67200 nM
Compound 4 ended at the assay's limit; the forecaster's own chance of this, stated with the estimate: 10%; at least 1.5-fold (0.19 log units) between middle value and limit.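

In this assay the change to oct-3-en-1-yl gave an at least 3.8-fold higher number from compound 3 to compound 4 (0.58 log units; beyond the scatter), the same direction as on the core of compound 1. Compound 4 stands at a limit of the assay, not at a number: the limit of > 67200 nM in this assay, at which 1 of the 4 values shown sits. The direction therefore carried from one core to the other in this pair of cases, but whether the size carried remains unsettled: the same change on two cores in this assay, a 2.5-fold higher number (0.39 log units; beyond the scatter) from compound 1 to compound 2 and an at least 3.8-fold higher number (0.58 log units; beyond the scatter) from compound 3 to compound 4; the limit leaves it open whether they differ.

The compounds shown leave open how much of the step belongs to the shorter chain and how much to the loss of double bonds, since both differ at once. They also leave open how either core behaves with a longer chain or a fully saturated chain.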